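This account rests on a few compounds, and the source may have more. Where it says the series, first, only, none or still open, it means among the compounds named here.

Measured compounds in a functional assay on the whole organism for inhibition, with Homo sapiens as the target, read by hemolysis; on this read-out higher numbers stand for weaker inhibition and lower numbers for stronger inhibition:

Compound 1, `CC1=CCC([C@@]2(C)Cc3c(O)ccc(C(=O)O)c3O2)CC1`, gives 2100000 nM.
Compound 2, `COc1ccc(C(=O)O)c2c1C[C@](C)(C1CC=C(C)CC1)O2`, gives 680000 nM.
Compound 3, `CC1=CCC([C@]2(C)Cc3c(O)cc(C=O)cc3O2)CC1`, gives 515000 nM.

Compound 1 and compound 2 differ in a single place: methyl in place of hydrogen on an oxygen on an aromatic ring. This change gave a 3.1-fold lower number from compound 1 to compound 2 (0.49 log units; beyond the scatter) in this assay. Compound 3 carries a different core; how the core of compound 3 differs from the core of compound 1 is not broken down here. Its value sits near that of compound 2, with compound 1 well apart from both.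

Compound 4, `COc1cc(C=O)cc2c1C[C@@](C)(C1CC=C(C)CC1)O2`, has not yet been measured. It relates to compound 3 through (methyl in place of hydrogen on an oxygen on an aromatic ring). The place of this change is word for word the same as for the earlier pair, so it counts as the same change. Within the data shown here, on the single earlier instance, the step from compound 3 to compound 4 is expected to be a 2.7-fold lower number from compound 3 to compound 4 (0.43 log units; beyond the scatter) in this assay, though one instance gives a thin basis and the new core may answer differently. Compound 4 is thus estimated at 190000 nM, with a range from 80000 nM to 480000 nM.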

Compound 4, half-maximal inhibitory concentration: > 1040000 nM
Compound 4: no number, only a limit; the forecaster's own chance of this, stated with the estimate: 5%; at least 5.4-fold (0.73 log units) between middle value and limit.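

In this assay compound 4 reads > 1040000 nM, which is a limit of the assay and not a number. Hydroxy to methoxy gives an at least 2.0-fold higher number from compound 3 to compound 4 (0.30 log units; that floor lies within the scatter), so the change does not carry from one core to the other with the same outcome: the same change on two cores in this assay, a 3.1-fold lower number (0.49 log units; beyond the scatter) from compound 1 to compound 2 and an at least 2.0-fold higher number (0.30 log units; that floor lies within the scatter) from compound 3 to compound 4, at least 6.2-fold (0.79 log units) apart, beyond the scatter of two such steps

From the compounds shown here alone, this rests on one pair per core, the full size of the step on the core of compound 3 remains unknown, and the pairs do not show what in the cores sets the difference.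

Still open, going by these compounds, is whether a longer chain in place of methyl on the oxygen follows the same split between the two cores. On these data alone, an amine in place of the hydroxy is equally open on either core.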